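Benzyl for Ethyl on the Ring Nitrogen

The compounds below may be only part of what the source reports. "The series", "measured", "known", "first", "only" and "open" are said of these compounds alone.

Measured in a functional assay on trachea (Cavia porcellus); a lower number here means a stronger inhibitor, a higher number a weaker inhibitor:
compound 1, `CO[C@@]12CCN(Cc3ccccc3)C[C@H]1[C@H](c1ccc3ccccc3c1)C(C#N)=C(N)O2`: 23400 nM
compound 2, `CO[C@@]12CCN(Cc3ccccc3)C[C@H]1[C@H](c1ccc(Cl)cc1)C(C#N)=C(N)O2`: 18500 nM
compound 3, `CCN1CC[C@@]2(OC)OC(N)=C(C#N)[C@@H](c3ccc(OC)cc3)[C@@H]2C1`: 25500 nM

The three numbers lie close together; compound 3 stands within the usual scatter of compound 1 and of compound 2, so no order among them can be read. Compound 4, `COc1ccc([C@@H]2C(C#N)=C(N)O[C@]3(OC)CCN(Cc4ccccc4)C[C@@H]23)cc1`, differs from compound 3 by phenyl in place of methyl on a saturated chain carbon bound to an amine nitrogen in a ring. Going by the values given here, no measured pair isolates this change. Among the compounds with values here, the only measured step, a 1.3-fold lower number from compound 1 to compound 2 (0.10 log units; within the scatter), concerns the aryl group on the saturated ring carbon and stays within the scatter. Compound 1 and compound 2 already carry the benzyl group on the ring nitrogen and give numbers within the scatter of compound 3. The step is therefore expected to be about a 1.2-fold lower number from compound 3 to compound 4 (0.08 log units; within the scatter), none beyond the scatter, in this assay. Compound 4 is therefore estimated at 21000 nM, with a range from 8000 nM to 55000 nM.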

Compound 4, half-maximal inhibitory concentration: 23100 nM
Compound 4: middle estimate off by 1.1-fold (0.04 log units), on the low side; measured number inside the range.
By their numbers in this assay, from the lowest: compounds 2, 4, 1 and 3 (each within the scatter of the next).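

In this assay, phenyl in place of methyl on a saturated chain carbon bound to an amine nitrogen in a ring gives a 1.1-fold lower number from compound 3 to compound 4 (0.04 log units; within the scatter), so ethyl and benzyl read alike here when 4-methoxyphenyl is held fixed. With benzyl held fixed, the aryl changes also stay flat: methoxy in place of chloro on an aromatic carbon gives a 1.2-fold higher number from compound 2 to compound 4 (0.10 log units; within the scatter), and 4-methoxyphenyl in place of naphthalen-2-yl gives a 1.0-fold lower number from compound 1 to compound 4 (0.01 log units; within the scatter). Nothing available explains this flat reading. The compounds shown leave open whether a carboxylic acid or a longer chain at this place would shift the number.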